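Swapping a Six-Membered Amine Ring for a Seven-Membered One

The source may report more compounds than this note shows. Statements on the series, on what has been measured and on what is new or still open speak of the compounds shown alone.

Measured compounds:
Compound 1, `CC1CCN(c2nc(Cc3c(F)cccc3F)cc(=O)[nH]2)CC1`, gives > 78000 nM, a limit of the test.
Compound 2, `O=c1cc(Cc2c(F)cccc2F)nc(N2CCCCCC2)[nH]1`, gives > 78000 nM, also a limit of the test.
Compound 3, `Cc1c(C(C)c2c(F)cccc2F)nc(N2CCC(C)CC2)[nH]c1=O`, gives 54000 nM.

All three were tested in an ADME assay on MT4 cells (Homo sapiens) for cytotoxicity, read by MTT assay, with a stated time of 4 days; on this read-out lower numbers stand for higher toxicity in this test and higher numbers for lower toxicity in this test. For compound 1 and for compound 2 the test reports only a limit, so the step that the two limits leave unreadable from compound 1 to compound 2 cannot be read. The change behind that step is azepan-1-yl in place of 4-methylpiperidin-1-yl on an aromatic carbon. Compound 3 rests on a different core, and the difference between the core of compound 1 and the core of compound 3 is not broken down here.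

The compound still to be measured, compound 4, `Cc1c(C(C)c2c(F)cccc2F)nc(N2CCCCCC2)[nH]c1=O`, is made from compound 3 by azepan-1-yl in place of 4-methylpiperidin-1-yl on an aromatic carbon. Among the compounds with values here, this is the same kind of change as the one from compound 1 to compound 2, but not the same: in compound 1 the place is meta to a group of 9 heavy atoms, while in compound 3 it is meta to a large group and para to a methyl group. What is known of this change is thin, because of the limit of > 78000 nM in this assay, at which 2 of the 3 values shown sit.

Within the data shown here, the step of a 1.1-fold higher number from compound 3 to compound 4 (0.05 log units; within the scatter) is expected to be small, resting on compound 3 at 54000 nM as the only number in hand. Compound 4 is therefore estimated to give about 60000 nM in this assay, in a range from 30000 nM to 120000 nM, with a fair chance that the test reports only a limit.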

Compound 4, half-maximal cytotoxic concentration: > 72000 nM
Compound 4 ended at the assay's limit; the forecaster's own chance of this, stated with the estimate: 40%; middle value at least 1.2-fold (0.07 log units) from the limit.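

On the core of compound 3, azepan-1-yl in place of 4-methylpiperidin-1-yl gives an at least 1.3-fold higher number from compound 3 to compound 4 (0.12 log units; that floor lies within the scatter) in this assay, and since that floor lies within the usual scatter, the step does not establish a real difference between the two compounds. Compound 4 gives > 72000 nM, which is a limit of the test and not a number, so the step has a floor but no known size. What carries over between the cores is therefore modest: on both, the compound with azepan-1-yl ends at a limit, yet the size of the change cannot be compared between the cores, because the step on the core of compound 1 has a limit at both ends and cannot be read: the limit of > 78000 nM in this assay, at which 2 of the 4 values shown sit.

The compounds shown leave open whether this change has any measurable size on either core, as compound 3 is the only one of the four with a number in this assay. They also leave open whether another amine in the same place, such as morpholin-4-yl or piperazin-1-yl, would give a number rather than a limit on the core of compound 3.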